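The source may report more compounds than this note shows. Statements on the series, on what has been measured and on what is new or still open speak of the compounds shown alone.

Compound 2 `CC(C)c1onc(-c2c(Cl)cccc2Cl)c1COc1ccc(-c2nc3ccc(C(=O)O)cc3n2Cc2ccc(F)cc2)cc1` stands second highest of the three measured numbers in an assay on Huh-7 cells for agonist activity at Bile acid receptor (Homo sapiens), read by a luciferase reporter; on this read-out lower numbers stand for an effect already at smaller amounts and higher numbers for an effect only at larger amounts of compound. Its nearest neighbour is compound 1 `CCC(CC)n1c(-c2ccc(OCc3c(-c4c(Cl)cccc4Cl)noc3C(C)C)cc2F)nc2ccc(C(=O)O)cc21`, whose value in this assay is 1.3 nM, set against 3.31 nM for compound 2. The furthest is compound 3 `CC(C)c1onc(-c2c(Cl)cccc2Cl)c1COc1ccc(-c2nc3cc(C(=O)O)ccc3n2C)cc1`, which in this assay gives 25.8 nM. Compound 4 `CCCn1c(-c2ccc(OCc3c(-c4c(Cl)cccc4Cl)noc3C(C)C)cc2)nc2ccc(C(=O)O)cc21` differs from compound 2 by ethyl in place of 4-fluorophenyl on a saturated chain carbon bound to an aromatic nitrogen. For the measured compounds named here, no measured pair shows this change directly; compound 1 with its longer branched chain and compound 3 with its methyl bracket the propyl of compound 4. Compound 4 is therefore expected to sit near compound 2, with a step from compound 2 to compound 4 of a 1.4-fold higher number from compound 2 to compound 4 (0.13 log units; within the scatter), likely within the scatter. Compound 4 is estimated at 4.5 nM, between 1.5 nM and 14 nM.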

Compound 4, half-maximal effective concentration: 9.3 nM
Compound 4: middle estimate off by 2.1-fold (0.32 log units), on the low side; low and high end bracket the measured number.
By their numbers in this assay, from the lowest: compound 1; then compound 2; then compound 4; then compound 3.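

In this assay, ethyl in place of 4-fluorophenyl on a saturated chain carbon bound to an aromatic nitrogen gives a 2.8-fold higher number from compound 2 to compound 4 (0.45 log units; beyond the scatter). For the compounds shown here, this is the first direct reading at this place, and it shows that the change counts, though only modestly: the aromatic ring can leave and the number shifts by a limited step. Nothing measured here bears on what lies behind this step. As far as these compounds go, it remains open whether unsubstituted phenyl in the same place would stand with compound 2, and where a longer chain such as butyl would fall.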